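The source may report more compounds than this note shows. Statements on the series, on what has been measured and on what is new or still open speak of the compounds shown alone.

Measured so far in an ADME assay on A549 cells (Homo sapiens) for cytotoxicity, read by resazurin assay, with a stated time of 48 h; on this read-out higher numbers stand for lower toxicity in this test and lower numbers for higher toxicity in this test:

Compound 1 `CCCCCCCCC(C)Nc1ccc(NC(=O)c2cc(Cl)ccc2O)c(Cl)c1`: 21900 nM
Compound 2 `CCN(CC)c1ccc(NC(=O)c2cc(Cl)ccc2O)c(Cl)c1`: 55500 nM

Compound 2 holds the highest of the two numbers recorded in this assay; its nearest neighbour is compound 1, whose number is lower by a step that lies beyond the usual scatter. Going by the values given here, no pair that differs in a single place has been measured, so nothing yet shows how a change at this position of the shared core moves the read-out.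

Compound 3 `O=C(Nc1ccc(NCc2cnccc2Cl)cc1Cl)c1cc(Cl)ccc1O` is the next case. It departs from compound 2 at one point: ((4-chloropyridin-3-yl)methyl)amino in place of diethylamino on an aromatic carbon. Among the compounds with values here, the new group brings a ring and a hydrogen-bond donor where compound 2 has none at this position, but with only two measured compounds there is no measured step of this kind to lean on.

The expectation is therefore cautious: a modest step down from compound 2 in this assay, of a size at or a little beyond the scatter, is expected as a 1.6-fold lower number from compound 2 to compound 3 (0.20 log units; within the scatter). Compound 3 is estimated at 35000 nM, with a range from 12000 nM to 100000 nM.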

Compound 3, half-maximal cytotoxic concentration: 126000 nM
The estimate for compound 3 lay 3.6-fold (0.56 log units) below the measured number; the whole stated range lies below it.
By their numbers in this assay, from the lowest: compound 1; then compound 2; then compound 3.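

In this assay, going by these compounds alone, ((4-chloropyridin-3-yl)methyl)amino in place of diethylamino on an aromatic carbon gives a 2.3-fold higher number from compound 2 to compound 3 (0.36 log units; beyond the scatter), the first single-place step, and it lies beyond the scatter. This position can therefore carry a group with more heavy atoms, a six-membered aromatic ring and a hydrogen-bond donor, and the read-out moves toward lower toxicity in this test, although the step is only modest. Within the data shown here, nothing measured so far accounts for this step.

The change alters several features at once, so the pair does not show whether the ring, the ring nitrogen, the ring chlorine or the amine hydrogen carries the step; a benzylamino group or a (pyridin-3-yl)methylamino group at this position would begin to separate them. Also open, from the compounds shown here alone, is whether a simple ethylamino group or a methyl group on the linking amine nitrogen would move the number in the same direction, and whether this step holds on other versions of the shared core.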